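The source may report more compounds than this note shows. Statements on the series, on what has been measured and on what is new or still open speak of the compounds shown alone.

Notes on the series. Compound 1 `O=C1Nc2ccc(Cl)cc2/C1=N/NC(=S)Nc1ccc(Cl)cc1` and compound 2 `O=C1Nc2ccc(F)cc2/C1=N/NC(=S)Nc1ccc(Cl)cc1` share one core; compound 3 `Cc1ccc(NC(=S)N/N=C2\C(=O)N(Cc3ccc(F)cc3)c3ccc(Br)cc32)cc1` is built on a different core, and the difference between the two cores is not broken down here. Compound 4 `Cc1ccc(NC(=S)N/N=C2\C(=O)N(Cc3ccc(Cl)cc3)c3ccc(Br)cc32)cc1` is the counterpart of compound 3 that still awaits measurement.

In a functional assay on L1210 cells (Mus musculus), with a stated time of 48 h (on this read-out lower numbers stand for stronger inhibition and higher numbers for weaker inhibition), compound 2 gives 34000 nM and compound 1 gives 108000 nM. The change between them is chloro in place of fluoro on an aromatic carbon, and the step reads a 3.2-fold higher number from compound 2 to compound 1 (0.50 log units; beyond the scatter). In this assay compound 3 gives 190000 nM, the highest of the three numbers; against compound 1 it lies within the scatter, against compound 2 beyond it.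

Compound 4 differs from compound 3 by chloro in place of fluoro on an aromatic carbon. This is the same kind of change as from compound 2 to compound 1, not the same one: there the place is part of a fused or bridged system of two rings, meta to a fused ring and para to a fused ring, whereas here it sits on a six-membered aromatic ring of carbon only, para to a large group. For the measured compounds named here, only one measured example of the change exists, and it stands on the other core, so its transfer to compound 3 is uncertain. For compound 4 in this assay a step of a 2.0-fold higher number from compound 3 to compound 4 (0.30 log units; within the scatter) is expected, taken as smaller than the measured one because a 3.2-fold higher number from compound 2 to compound 1 (0.50 log units; beyond the scatter) rests on a single pair and a different core. Compound 4 is accordingly estimated at 380000 nM, with a range from 150000 nM to 1000000 nM.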

Compound 4, half-maximal inhibitory concentration: >= 500000 nM
Compound 4: only a limit was reported; the forecaster's own chance of this, stated with the estimate: 25%; at least 1.3-fold (0.11 log units) between middle value and limit.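

Replacing 4-fluorobenzyl with 4-chlorobenzyl in this assay gives an at least 2.6-fold higher number from compound 3 to compound 4 (0.42 log units; beyond the scatter), so the number rises in the same direction on both cores, on one pair per core and with the halogen at a different place on each. For compound 4, the reported >= 500000 nM is a limit and not a number, so the new step gives only a lower bound on the size of the change. The direction therefore carries over between these two pairs, but nothing shows that the size does, and two pairs do not make a rule for the series: the same change on two cores in this assay, a 3.2-fold higher number (0.50 log units; beyond the scatter) from compound 2 to compound 1 and an at least 2.6-fold higher number (0.42 log units; beyond the scatter) from compound 3 to compound 4; the limit leaves it open whether they differ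

The compounds shown leave open whether the same rise appears when the halogen on the benzyl ring gives way to a methoxy group, a trifluoromethyl group or an amine, and whether it holds at other places on that ring. They also leave open how much of the distance between the two series belongs to the core itself, as no pair shown differs in the core alone, and how far compound 4 lies beyond its limit.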